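Back from Benzyl to a Branched Alkyl Chain

The compounds below may be only part of what the source reports. "The series", "measured", "known", "first", "only" and "open" are said of these compounds alone.

Compound 1 `Cc1nc2ccc(-c3ccc(CN4CCC[C@@H]4CO)cc3)cc2n1CCC(C)C` and compound 2 `Cc1nc2ccc(-c3ccc(CN4CCC[C@@H]4CO)cc3)cc2n1Cc1ccccc1` share the same core and differ only in the group on the saturated chain carbon bound to the aromatic nitrogen. In an assay on cells for inhibition of sphingosine kinase 1 (Homo sapiens), read by fluorescence polarization, with stated times of 15 min and 1 h (a lower number here means a stronger inhibitor, a higher number a weaker inhibitor), compound 1 gives 7 nM, while compound 2 gives 440 nM. That change amounts to a 63-fold higher number from compound 1 to compound 2 (1.80 log units; beyond the scatter), so compound 2 stands at the weaker end of the two measured numbers, its nearest neighbour being compound 1. Compound 3 `Cc1nc2ccc(-c3ccc(CN4CCC[C@@H]4CO)cc3)cc2n1CC(C)C` has not yet been measured. Its difference from compound 2 is isopropyl in place of phenyl on a saturated chain carbon bound to an aromatic nitrogen. Among the measured compounds shown here, the only measured step that bears on this is the one from compound 1 to compound 2, which was large and ran toward a weaker inhibitor; compound 3 reverses that change, though it carries isopropyl where compound 1 carries isobutyl. The analyst therefore expects compound 3 to come out a clearly stronger inhibitor than compound 2, with an expected step of a 29-fold lower number from compound 2 to compound 3 (1.47 log units; beyond the scatter) in this assay. The estimate for compound 3 is 15 nM, with a range from 4 nM to 60 nM.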

Compound 3, half-maximal inhibitory concentration: 290 nM
The estimate for compound 3 lay 19-fold (1.29 log units) below the measured number; the whole stated range lies below it.
By their numbers in this assay, from the lowest: compound 1; then compounds 3 and 2 (each within the scatter of the next).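

Exchanging the phenyl for isopropyl at this place, on a saturated chain carbon bound to an aromatic nitrogen, brought almost no gain in this assay: the change gives a 1.5-fold lower number from compound 2 to compound 3 (0.18 log units; within the scatter). Losing the aromatic ring was therefore not enough on its own to recover the low number of compound 1, and the large gap seen earlier cannot be credited simply to phenyl against a branched alkyl group. The decisive contrast now lies within the alkyl series, where the shorter branched chain of compound 3 gives a 41-fold higher number from compound 1 to compound 3 (1.62 log units; beyond the scatter), although nothing measured here explains this sensitivity to the isobutyl group of compound 1.

The three compounds leave open whether the branching matters or the chain length alone, which a straight butyl or pentyl chain on the same nitrogen could separate. They also leave open whether a longer branched chain would go further than the isobutyl group of compound 1, and whether a cyclohexyl ring carried on a longer chain would behave like that group.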